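Methyl on the Benzyl Ring: Expectation for Compound 4

The source may hold more compounds than are shown below. What is called first, only, known or untested is meant among the compounds shown, and "the series" means these compounds.

The series shares the core of compound 1, `CCc1cc(=O)c2ccc(Sc3cccc(Cl)n3)cc2o1`. In a functional assay on DU-145 cells (Homo sapiens) for antiproliferative activity, read by sulforhodamine B assay, with a stated time of 72 h (a lower number here means a stronger inhibitor of growth, a higher number a weaker inhibitor of growth), compound 1 gives > 31400 nM, which is a limit of the assay and not a number. Compound 2, `CCc1cc(=O)c2ccc(Sc3cccc(Cl)n3)c(C)c2o1`, carries methyl in place of hydrogen on an aromatic carbon. In this assay compound 2 gives > 30100 nM, again a limit rather than a number. The step that the two limits leave unreadable from compound 1 to compound 2 therefore cannot be read, as compound 1 sits at the limit of > 31400 nM in this assay, at which 1 of the 3 values shown sits, and compound 2 sits at the limit of > 30100 nM in this assay, at which 1 of the 3 values shown sits.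

Compound 3, `CCc1cc(=O)c2ccc(OCc3ccccc3)c(C)c2o1`, differs from compound 1 in more than one place; the difference between the two cores is not broken down here. In this assay, going by the values given here, compound 3 gives 27700 nM, the only number among the three values shown.

Compound 4, `CCc1cc(=O)c2ccc(OCc3cccc(C)c3)c(C)c2o1`, has not yet been measured. It carries methyl in place of hydrogen on an aromatic carbon. Among the compounds with values here, this is the same kind of change as the one from compound 1 to compound 2, but at another place: in compound 2 the methyl sits on an aromatic carbon of a six-membered aromatic ring of carbon only, part of a fused or bridged system of two rings, ortho to a fused ring, ortho to a group of 8 heavy atoms and meta to a fused ring, whereas in compound 4 it sits on a six-membered aromatic ring of carbon only, meta to a large group. The earlier step has no readable size, so nothing measured sets the size of the new one. The expectation rests on compound 3 at 27700 nM and on the single heavy atom that enters. In this assay compound 4 is expected to give 22000 nM, between 8000 nM and 50000 nM. The expected step of a 1.3-fold lower number from compound 3 to compound 4 (0.10 log units; within the scatter) stays within the usual scatter.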

Compound 4, concentration for 50% growth inhibition: 24100 nM
The estimate for compound 4 lay 1.1-fold (0.04 log units) below the measured number; the range from low to high includes it.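

In this assay, the methyl in place of hydrogen on an aromatic carbon, which turns phenyl into 3-methylphenyl, appears as a 1.1-fold lower number from compound 3 to compound 4 (0.06 log units; within the scatter), so on the core of compound 3 this change, at this place, leaves nothing that can be told apart from the scatter of repeated measurements. The same kind of change on the core of compound 1, made at another place, cannot be read, as compound 1 and compound 2 each give a limit of the assay and not a number. Going by these compounds alone, the account therefore does not show whether the change carries from one core to the other: there is only one readable step, on one core, and the methyl sits at a different place in each case, so no comparison of the two steps can be made.

The compounds shown leave open whether any other group on this ring, such as an amine, a carboxylic acid or a longer chain in place of the methyl, would give a step beyond the scatter. They also leave open what the 3-methylphenyl change would do on the core of compound 1, where a readable number would be needed on both sides of the step.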